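Sulfamoylethyl Replaces Dihydroxypropyl on an Amide Nitrogen

This account rests on a few compounds, and the source may have more. Where it says the series, first, only, none or still open, it means among the compounds named here.

Three compounds share one core. Compound 2 `NCc1cc(Oc2cccc(C(=O)NC[C@@H](O)CO)c2)nc(C(F)(F)F)c1` and compound 3 `NCc1cc(Oc2cccc(C(=O)Nc3ccccc3)c2)nc(C(F)(F)F)c1` were measured in an ADME assay on the whole organism (plasma, Mus musculus) for pharmacokinetics, read by LC-MS, at a dose of 30 mg/kg by the oral route (a lower number here means less compound in the circulation, a higher number more compound in the circulation at the dose given), while compound 1 `NCc1cc(O[C@@H]2CCCN(C(=O)Nc3ccccc3)C2)nc(C(F)(F)F)c1` stands there as "not determined" (no result reported). In this assay compound 2 gives 2770 nM, the higher of the two numbers, and compound 3 gives 860 nM. Within the data shown here, the only measured step, a 3.2-fold lower number from compound 2 to compound 3 (0.51 log units; beyond the scatter), puts a phenyl in place of a 2,3-dihydroxypropyl. Compound 4 `NCc1cc(Oc2cccc(C(=O)NCCS(N)(=O)=O)c2)nc(C(F)(F)F)c1` alters compound 2 differently: sulfamoylmethyl in place of 1,2-dihydroxyethyl on a saturated chain carbon bound to an amide-type nitrogen. Here one chain is exchanged for another chain rather than for a ring, so the drop seen with compound 3 is only a weak guide. The expected step is a 1.4-fold lower number from compound 2 to compound 4 (0.14 log units; within the scatter), within the scatter. The estimate for compound 4 is 2000 nM, between 800 nM and 5000 nM.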

Compound 4, maximal plasma concentration: 1040 nM
The estimate for compound 4 lay 1.9-fold (0.28 log units) above the measured number; low and high end bracket the measured number.
By their numbers in this assay, from the lowest: compounds 3 and 4 (each within the scatter of the next); then compound 2.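

Compound 2 no longer stands apart merely as the compound with a chain rather than a ring on the amide-type nitrogen. Exchanging one chain for another gives a 2.7-fold lower number from compound 2 to compound 4 (0.43 log units; beyond the scatter) in this assay, while replacing phenyl with 2-sulfamoylethyl gives a 1.2-fold higher number from compound 3 to compound 4 (0.08 log units; within the scatter), so compound 4 goes against any simple chain-over-ring pattern. No available measurement explains this difference. Still open, on these data alone, is whether a 2-hydroxyethyl chain, a carboxylic acid or an amine on this nitrogen would give a number like that of compound 2 or like those of compound 3 and compound 4.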